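This account rests on a few compounds, and the source may have more. Where it says the series, first, only, none or still open, it means among the compounds named here.

Measured compounds:
- compound 1, `CCCOC(=O)C1=C(C)NC(=S)NC1c1ccoc1`, in an assay on membranes from CHO cells for displacement of a labelled ligand from adenosine receptor A1 (Homo sapiens), read by scintillation counting, with a stated time of 60 min, tested at 1 uM (on this read-out lower numbers stand for less inhibition and higher numbers for more inhibition at the one concentration tested (going by the name of the read-out)), compound 1 gives 4%
- compound 2, `CC1=C(C(=O)OCC(C)C)C(c2ccoc2)NC(=S)N1`, in this assay compound 2 gives 12%
- compound 3, `CCSC(=O)C1=C(C)NC(=O)NC1c1ccco1`, in this assay compound 3 gives 6%

All three numbers are low and sit close together. Among the compounds with values here, the one step that can be counted is a number 8 percentage points higher from compound 1 to compound 2 (within the scatter), the change being (methyl in place of hydrogen on a saturated chain carbon bound to two saturated chain carbons). Compound 3 carries a different core from compound 1; the difference between the two cores is not broken down here. Compound 3 and compound 1 differ in their read-outs by an amount that is within the scatter, as do compound 3 and compound 2.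

Compound 4, `CC1=C(C(=O)SC(C)C)C(c2ccco2)NC(=O)N1`, is not yet measured. It differs from compound 3 by methyl in place of hydrogen on a saturated chain carbon bound to a saturated chain carbon and a sulfur. Within the data shown here, this is the same kind of change as the one from compound 1 to compound 2, but not the same: in the earlier pair the place is on a saturated chain carbon bound to two saturated chain carbons, whereas here the place is on a saturated chain carbon bound to a saturated chain carbon and a sulfur.

Among the measured compounds shown here, the only guide for the size of the step is the earlier pair, where the step was within the scatter; the expected step for compound 4 in this assay is therefore a number 4 percentage points higher from compound 3 to compound 4 (within the scatter), resting on compound 3 at 6% and on the size of a number 8 percentage points higher from compound 1 to compound 2 (within the scatter). For compound 4 the estimated read-out is 10%, expected to fall between 0% and 25%.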

Compound 4, a percentage reported as inhibition, at one concentration (the size of the read-out at that concentration, not a potency): 5%
The estimate for compound 4 lay 5 percentage points above the measured number, and the stated range covers the measured number.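

In this assay, putting methyl in place of hydrogen on a saturated chain carbon bound to a saturated chain carbon and a sulfur, which turns the (ethylsulfanyl)carbonyl group into the (isopropylsulfanyl)carbonyl group, gives a number 1 percentage points lower from compound 3 to compound 4 (within the scatter). Set beside the earlier case, the same kind of change does not read differently on the two cores: the same change on two cores in this assay, a number 8 percentage points higher (within the scatter) from compound 1 to compound 2 and a number 1 percentage points lower (within the scatter) from compound 3 to compound 4, 9 percentage points apart, within the scatter of two such steps

This shows only that the added methyl produced no step beyond the scatter on either core, so nothing here argues against carrying the change across, but it does not show that a real effect of the same size carries over, since both steps are small, all four compounds read low at the one concentration tested, the two places are not identical, and each core is represented by a single pair.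

Open is whether a longer chain, such as n-butyl or n-hexyl, in this same place would lift the read-out clearly above that of these compounds. Also open, on these data alone, is how an amine or a carboxylic acid at the end of that chain would read, and whether the methyl step would hold on a compound with a higher starting read-out.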